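Hydroxy for Chloro on Two Different Cores

The source may hold more compounds than are shown below. What is called first, only, known or untested is meant among the compounds shown, and "the series" means these compounds.

In an ADME assay on L1210/0 cells (Mus musculus) for cytotoxicity, with a stated time of 48 h (on this read-out higher numbers stand for weaker inhibition and lower numbers for stronger inhibition), three compounds have been measured so far:
compound 1, `CC1(C)[C@@H](Cn2cnc3c(Cl)nc(N)nc32)CC[C@@]1(C)CO`: 50000 nM
compound 2, `CC1(C)[C@@H](Cn2cnc3c(O)nc(N)nc32)CC[C@@]1(C)CO`: a limit only, > 200000 nM
compound 3, `Nc1nc2c(nc(Cl)n2COCCO)c(=O)[nH]1`: a limit only, > 200000 nM

Compound 1 and compound 2 differ by hydroxy in place of chloro on an aromatic carbon; this change gave an at least 4.0-fold higher number from compound 1 to compound 2 (0.60 log units; beyond the scatter). Compound 4, `Nc1nc2c(nc(O)n2COCCO)c(=O)[nH]1`, is not yet measured and differs from compound 3 by hydroxy in place of chloro on an aromatic carbon, the same kind of change, though here it sits on a five-membered aromatic ring with 2 nitrogen, between two ring nitrogen atoms, next to the ring atom that bears a (2-hydroxyethoxy)methyl group, rather than on a six-membered aromatic ring with 2 nitrogen. How the core of compound 3 differs from the core of compound 1 is not broken down here. Because compound 3 already sits at the limit of > 200000 nM in this assay, at which 2 of the 3 values shown sit, the step that the limit leaves unreadable from compound 3 to compound 4 is expected to keep compound 4 there as well. Compound 4 is therefore estimated at 300000 nM, with a range from 150000 nM to 1000000 nM, most likely again only as a limit.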

Compound 4, half-maximal inhibitory concentration: > 200000 nM
Compound 4: no number, only a limit; the forecaster's own chance of this, stated with the estimate: 90%; the middle value lies beyond the limit too.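

In this assay, compound 3 and compound 4 both stand only as limits, so no step between them can be read: the limit of > 200000 nM in this assay, at which 3 of the 4 values shown sit.

On these data alone, whether hydroxy in place of chloro changes the read-out on the core of compound 3, as it does on the core of compound 1, stays open.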